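Chlorine-bearing carboxyphenyl variant of a glutamate receptor modulator

A few compounds are considered here, and "the series" means these few. Any claim that something is new, unique, unknown or untested is made for them only; others in the source may bear on it.

compound 1 `Cc1c(OCCCCOCOc2ccc(C(=O)O)cc2)ccc(C(=O)CC2CCCC2)c1O`: 95.4%
compound 2 `Cc1c(OCCCCOc2cccc(C(=O)O)c2)ccc(C(=O)CC2CCCC2)c1O`: 80.6%

In an assay on HEK293 cells for positive allosteric modulation of metabotropic glutamate receptor 2 (Rattus norvegicus), read by thallium flux, with a stated time of 2.5 min (on this read-out higher numbers stand for larger maximal responses and lower numbers for smaller maximal responses), compound 2 gives 80.6%, the lower of the two numbers, while compound 1 gives 95.4%; the step of a number 14.8 percentage points lower from compound 1 to compound 2 (beyond the scatter) separates them. Compound 3 `Cc1c(OCCCCOc2ccc(C(=O)O)c(Cl)c2)ccc(C(=O)CC2CCCC2)c1O` carries the change (4-carboxy-3-chlorophenyl in place of 3-carboxyphenyl on an oxygen on a saturated carbon). Among the compounds with values here, no measured step covers this change; the one step measured concerns a different group and gives only a rough idea of how much this region can shift the response. The expected step is therefore small, a number 5.4 percentage points higher from compound 2 to compound 3 (within the scatter), leaning upward. Compound 3 is estimated at 86%, within 66% to 102%.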

Compound 3, largest response reached (reported as percent of maximum), in percent of the reference or control that the assay uses: 80.8%
For compound 3 the middle estimate is 5.2 percentage points above the measured one; the measured number falls inside the stated range.
By their numbers in this assay, from the lowest: compounds 2 and 3 (each within the scatter of the next); then compound 1.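

In this assay, putting 4-carboxy-3-chlorophenyl in place of 3-carboxyphenyl on this oxygen-linked chain leaves the maximal response level, with a number 0.2 percentage points higher from compound 2 to compound 3 (within the scatter). The new ring also stays short of the (4-carboxyphenoxy)methyl group, with a number 14.6 percentage points lower from compound 1 to compound 3 (beyond the scatter), so both rings now sit apart from compound 1. Nothing available explains either step. On these data alone, this swap changes the chlorine and the place of the carboxylic acid together, so their separate contributions remain unknown. As far as these compounds go, whether a fluorine or a methyl group could stand in for the chlorine also remains open.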